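A few compounds are considered here, and "the series" means these few. Any claim that something is new, unique, unknown or untested is made for them only; others in the source may bear on it.

- Compound 1 `CCNc1nc(S(=O)(=O)c2ccc(N)nc2)ccc1-c1ccc(C(C)(O)C(F)(F)F)cn1`: 42 mL.min-1.g-1
- Compound 2 `CC(O)(c1ccc(-c2ccc(S(=O)(=O)c3ccc(N)nc3)nc2NC2CC2)nc1)C(F)(F)F`: 43 mL.min-1.g-1
- Compound 3 `CC(O)(c1ccc(-c2ccc(S(=O)(=O)c3ccc(N)nc3)nc2NCc2ccccc2)nc1)C(F)(F)F`: 114 mL.min-1.g-1

All three numbers come from an ADME assay (liver) for metabolic stability, with Liver microsome (Rattus norvegicus) as the target, using microsomes and NADPH, with a stated time of 30 min, at 37 degrees C, tested at 1 uM; a higher number here means faster removal of the compound, a lower number slower removal. Compound 3 stands highest of the three, and both of the others lie clearly lower. Compound 4 `CC(O)(c1ccc(-c2ccc(S(=O)(=O)c3ccc(N)nc3)nc2Nc2ccccn2)nc1)C(F)(F)F` has pyridin-2-yl in place of benzyl on a nitrogen on an aromatic ring.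

The measured steps at this same nitrogen give some guidance. Replacing ethyl with cyclopropyl changed little: a 1.0-fold higher number from compound 1 to compound 2 (0.01 log units; within the scatter). The larger changes came with benzyl, and both were modest: a 2.7-fold higher number from compound 1 to compound 3 (0.43 log units; beyond the scatter) and a 2.7-fold higher number from compound 2 to compound 3 (0.42 log units; beyond the scatter). Benzyl is the group that leaves in compound 4, so part of that rise is expected to disappear. Not all of it need go, since pyridin-2-yl also brings a six-membered aromatic ring. Going by the values given here, no measured compound carries pyridin-2-yl, so this expectation remains uncertain and the range must stay wide.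

The expected change is a 1.9-fold lower number from compound 3 to compound 4 (0.28 log units; within the scatter), a step toward lower numbers. For compound 4 the estimate is 60 mL.min-1.g-1, with an expected range from 30 mL.min-1.g-1 to 115 mL.min-1.g-1.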

Compound 4, intrinsic clearance in microsomes: 130 mL.min-1.g-1
Compound 4: the middle estimate sits 2.2-fold (0.34 log units) below what was measured; measured number above the stated range.
By their numbers in this assay, from the lowest: compounds 1 and 2 (each within the scatter of the next); then compounds 3 and 4 (each within the scatter of the next).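

In this assay, pyridin-2-yl in place of benzyl gives a 1.1-fold higher number from compound 3 to compound 4 (0.06 log units; within the scatter), so these two groups cannot be told apart here, even though the swap adds a ring nitrogen with its hydrogen-bond acceptor and removes the chain carbon of benzyl. Pyridin-2-yl also stands clear of the two smaller groups, with a 3.0-fold higher number from compound 2 to compound 4 (0.48 log units; beyond the scatter) and a 3.1-fold higher number from compound 1 to compound 4 (0.49 log units; beyond the scatter), so among these four compounds, the two with a six-membered aromatic ring on this nitrogen give the higher numbers, and no compound shown goes against that. Nothing available explains why these groups give such numbers.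

From the compounds shown here alone, it remains open whether a saturated ring such as cyclohexyl on this nitrogen would fall with ethyl and cyclopropyl or with benzyl and pyridin-2-yl, and where pyridin-3-yl would fall. Going by these compounds, all four compounds also share the rest of their structure, so it is unknown whether the same gap would appear if a carboxylic acid replaced the alcohol-bearing trifluoromethyl group.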